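The source may hold more compounds than are shown below. What is called first, only, known or untested is meant among the compounds shown, and "the series" means these compounds.

Compound 1 `COc1cc2ncnc(NCc3cccc(NC(=O)Nc4cccc(C)c4)c3)c2cc1OC` — in a functional assay on HepG2 cells (Homo sapiens) for antiproliferative activity, read by MTT assay (a lower number here means a stronger inhibitor, a higher number a weaker inhibitor), compound 1 gives 21500 nM.
Compound 2 `COc1cc2ncnc(NCc3cccc(NC(=O)Nc4ccc(C)cc4)c3)c2cc1OC` — in this assay compound 2 gives > 50000 nM, which is a limit of the assay rather than a number.
Compound 3 `COc1ccccc1NC(=O)Nc1cccc(CNc2ncnc3cc(OC)c(OC)cc23)c1` — in this assay compound 3 gives 27200 nM.

All three share one core and differ only in the aryl group on the urea nitrogen. Compound 3 and compound 1 sit within the scatter of each other, as a 1.3-fold higher number from compound 1 to compound 3 (0.10 log units; within the scatter) shows. Among the measured compounds shown here, compound 2, by contrast, only reaches a limit (the limit of > 50000 nM in this assay, at which 1 of the 3 values shown sits), so the step of an at least 2.3-fold higher number from compound 1 to compound 2 (0.36 log units; beyond the scatter) is the single change here that clearly moved the number.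

Compound 4 `COc1ccc(NC(=O)Nc2cccc(CNc3ncnc4cc(OC)c(OC)cc34)c2)cc1` is the next member: 4-methoxyphenyl in place of 2-methoxyphenyl on an amide-type nitrogen. For the measured compounds named here, no measured step moves a methoxy group in this way, so the nearest guide is the methyl case, where placing the group at the 4-position raised the number to the limit. The step of an at least 1.8-fold lower number from compound 2 to compound 3 (0.26 log units; that floor lies within the scatter) is consistent with that reading. The expectation for compound 4 is therefore a rise of about a 1.7-fold higher number from compound 3 to compound 4 (0.22 log units; within the scatter) in this assay, with a real chance that only a limit is recorded. Compound 4 is thus estimated at 45000 nM, with a range from 18000 nM to 110000 nM.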

Compound 4, half-maximal inhibitory concentration: > 50000 nM
Compound 4: only a limit was reported (the forecaster's own chance of this, stated with the estimate: 40%); at least 1.1-fold (0.04 log units) between middle value and limit.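

In this assay, compound 2 with 4-methylphenyl and compound 4 with 4-methoxyphenyl both end at a limit of the assay, so the outcome first seen with methyl now also appears with methoxy: the limit of > 50000 nM in this assay, at which 2 of the 4 values shown sit.

Moving the methoxy group from 2-methoxyphenyl to 4-methoxyphenyl, with the same atoms joined differently, gives an at least 1.8-fold higher number from compound 3 to compound 4 (0.26 log units; that floor lies within the scatter), so this closest pair alone does not establish a real change. The firmer comparison is an at least 2.3-fold higher number from compound 1 to compound 4 (0.36 log units; beyond the scatter), which has the same reading as the earlier at least 2.3-fold higher number from compound 1 to compound 2 (0.36 log units; beyond the scatter), although this newer step changes both the group and where it sits on the ring.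

The step between compound 2 and compound 4 cannot be read, so the compounds shown do not tell whether methyl and methoxy differ when carried as 4-methylphenyl and 4-methoxyphenyl. Also open, on these data alone, is how a 4-aminophenyl or 4-carboxyphenyl group on the same amide-type nitrogen would read, and whether either would give a number rather than a limit.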